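Compound 3 to compound 4: saturating the ethenyl group

The compounds below may be only part of what the source reports. "The series", "measured", "known", "first", "only" and "open" are said of these compounds alone.

Measured in a functional assay on A2780 cells (Homo sapiens) for antiproliferative activity, read by sulforhodamine B assay, with a stated time of 48 h; a lower number here means a stronger inhibitor of growth, a higher number a weaker inhibitor of growth:
Compound 1 `CC(C)(C)[Si](C)(C)O[C@@H]1CCCO[C@@H]1CO`: > 100000 nM (a limit)
Compound 2 `CC(C)(C)[Si](C)(C)O[C@@H]1CCCO[C@@H]1COCC(=O)O`: > 100000 nM (a limit)
Compound 3 `COC(=O)/C=C/OC[C@H]1OCCC[C@H]1O[Si](C)(C)C(C)(C)C`: 30000 nM

Compound 3 is the only one of the three with a number rather than a limit. Compound 4 `COC(=O)CCOC[C@H]1OCCC[C@H]1O[Si](C)(C)C(C)(C)C` differs from it in one place: 2-(methoxycarbonyl)ethyl in place of 2-(methoxycarbonyl)ethenyl on an oxygen on a saturated carbon. Among the measured compounds shown here, two measured steps bear on this change: an at least 3.3-fold lower number from compound 1 to compound 3 (0.52 log units; beyond the scatter) and an at least 3.3-fold lower number from compound 2 to compound 3 (0.52 log units; beyond the scatter). The third, a step that the two limits leave unreadable from compound 1 to compound 2, offers no size. Only compound 3 carries the 2-(methoxycarbonyl)ethenyl, and only compound 3 gives a number, so a modest move toward a higher number is expected in this assay. The estimated change is a 2.0-fold higher number from compound 3 to compound 4 (0.30 log units; within the scatter). Compound 4 is expected at 60000 nM, with an estimated range of 25000 nM to 100000 nM.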

Compound 4, concentration for 50% growth inhibition: > 100000 nM
Compound 4: only a limit was reported (the forecaster's own chance of this, stated with the estimate: 35%); middle value at least 1.6-fold (0.22 log units) away from the limit.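

In this assay, the change from 2-(methoxycarbonyl)ethenyl to 2-(methoxycarbonyl)ethyl gives an at least 3.3-fold higher number from compound 3 to compound 4 (0.52 log units; beyond the scatter), so the methyl ester alone, on the same core, does not give compound 4 a measurable number; among these compounds, only the ethenyl form does. Compound 4 gives > 100000 nM, which is a limit. The steps that link compound 1 and compound 2 to compound 4 cannot be read: the limit of > 100000 nM in this assay, at which 3 of the 4 values shown sit.

Still open, from the compounds shown here alone, is whether an amide in place of the methyl ester would retain a number with the ethenyl kept. A longer chain ending in the ester is equally untested in the compounds shown.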